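Amidine side chain: ring amine moved closer to the nitrogen

The compounds below may be only part of what the source reports. "The series", "measured", "known", "first", "only" and "open" are said of these compounds alone.

Compound 2 `COc1ccc(Br)cc1CCc1c(F)cccc1C(=O)/N=C(\N)NCCCN1CCCCC1` is the reference for this step. In an assay for binding affinity to Melanocortin receptor 4 (Homo sapiens) (on this read-out higher numbers stand for weaker inhibition and lower numbers for stronger inhibition), compound 2 gives 3.2 nM, the lowest of the three numbers recorded so far. Among the measured compounds shown here, compound 1 `COc1ccc(Br)cc1CCc1c(F)cccc1C(=O)/N=C(\N)NCCC1CCCCC1` gives 2600 nM in this assay, and compound 3 `CCN(CC)CCCC(C)/N=C(/N)NC(=O)c1cccc(F)c1CCc1ccccc1Cl` gives 26000 nM; no single-point step links compound 3 to the other two, so its number is noted only as the highest of the set.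

For the measured compounds named here, the one measured step that bears on the change is an 810-fold lower number from compound 1 to compound 2 (2.91 log units; beyond the scatter), a large gain obtained when a chain end without a ring nitrogen was exchanged for one carrying a ring nitrogen.

Compound 4 `COc1ccc(Br)cc1CCc1c(F)cccc1C(=O)/N=C(\N)NCC1CCNCC1` differs from compound 2 as follows: piperidin-4-yl in place of 2-(piperidin-1-yl)ethyl on a saturated chain carbon bound to an amine nitrogen. The ring nitrogen is retained, but the chain between the amine nitrogen and the ring is shortened and the ring nitrogen now carries a hydrogen. Because the gain in an 810-fold lower number from compound 1 to compound 2 (2.91 log units; beyond the scatter) came with the arrival of a ring nitrogen, and compound 4 keeps one, a step of that size in either direction is not expected. A small loss is estimated, a 3.1-fold higher number from compound 2 to compound 4 (0.49 log units; beyond the scatter), with compound 4 expected at 10 nM, most likely between 2 nM and 60 nM.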

Compound 4, inhibition constant: 13 nM
Estimate against measurement, compound 4: 1.3-fold (0.11 log units) below, and the stated range covers the measured number.
By their numbers in this assay, from the lowest: compound 2; then compound 4; then compound 1; then compound 3.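

In this assay, the large gain seen with compound 2 does not depend on the 2-(piperidin-1-yl)ethyl group: with piperidin-4-yl on the same saturated chain carbon bound to an amine nitrogen, the series still shows a 200-fold lower number from compound 1 to compound 4 (2.30 log units; beyond the scatter). Set against compound 2, the same exchange costs far less, a 4.1-fold higher number from compound 2 to compound 4 (0.61 log units; beyond the scatter), so this position accepts both a shorter chain and a ring nitrogen carrying a hydrogen with only a modest change, though the step is beyond the scatter and the two features change together. No measured information is available to explain either step.

The step from compound 2 to compound 4 cannot show how much of the change belongs to the chain length and how much to the way the ring is attached, a question that 2-(piperidin-4-yl)ethyl or 1-methylpiperidin-4-yl at the same place would address. Also open, from the compounds shown here alone, is whether the ring is needed at all or an open-chain amine such as 3-(dimethylamino)propyl would serve on the shared core, as compound 3 carries a different core and cannot be read on this point.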